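This account rests on a few compounds, and the source may have more. Where it says the series, first, only, none or still open, it means among the compounds named here.

In an ADME assay on microsomes from liver (Homo sapiens) for metabolic stability, read by LC-MS, tested at 1 uM (a higher number here means that the compound lasts longer, a lower number that the compound disappears faster), compound 3 (`Cc1ccoc1C(=O)Nc1cccc(-c2nc3ncccc3o2)c1`) gives 0.167 h, level with compound 2 (`Cc1ccc(NC(=O)c2ccoc2)cc1-c1nc2ncccc2o1`) at 0.167 h and within the scatter of compound 1 (`Cc1ccoc1C(=O)Nc1ccc(F)c(-c2nc3ncccc3o2)c1`) at 0.15 h. Compound 4 (`Cc1ccc(NC(=O)c2occc2C)cc1-c1nc2ncccc2o1`) differs from compound 3 by methyl in place of hydrogen on an aromatic carbon, on an aromatic carbon of a six-membered aromatic ring of carbon only. For the measured compounds named here, the one measured step on that ring, a 1.1-fold higher number from compound 1 to compound 3 (0.05 log units; within the scatter), stayed within the scatter. Going by the values given here, compound 2 also carries a methyl on that ring and shows 0.167 h, although no step isolating a methyl has been measured. No change beyond the scatter is therefore expected in this assay, and the estimated step is a 1.1-fold lower number from compound 3 to compound 4 (0.05 log units; within the scatter). Compound 4 is expected at 0.15 h, within an estimated range of 0.08 h to 0.28 h.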

Compound 4, half-life in the Homo sapiens assay: 0.133 h
Compound 4: middle estimate off by 1.1-fold (0.05 log units), on the high side; low and high end bracket the measured number.
By their numbers in the Homo sapiens assay, from the lowest: compounds 4, 1, 2 and 3 (each within the scatter of the next).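

For the compounds shown here, in the Homo sapiens assay this is the first step that isolates a methyl on this ring, and it stays small: a 1.3-fold lower number from compound 3 to compound 4 (0.10 log units; within the scatter). The other two steps read the same way, with a 1.3-fold lower number from compound 2 to compound 4 (0.10 log units; within the scatter) for 3-methylfuran-2-yl in place of furan-3-yl and a 1.1-fold lower number from compound 1 to compound 4 (0.05 log units; within the scatter) for methyl in place of fluoro, so hydrogen, fluoro and methyl at this position are not told apart here. The methyl does register in a physicochemical assay for lipophilicity, read by HPLC, at pH 7.4 (on this read-out higher numbers stand for higher lipophilicity and lower numbers for lower lipophilicity), where compound 3 gives 2.9 and compound 4 gives 3.3, so higher lipophilicity came with no half-life change beyond the scatter: the measured distribution coefficient of compound 3, 2.9, and of compound 4, 3.3, a number 0.40 log units higher (beyond the scatter)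

Left open is whether an amine, a methoxy or a carboxylic acid on this carbon would move the half-life beyond the scatter, and whether it would bring the distribution coefficient back down.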